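Cytotoxicity of isoxazole esters bearing substituted benzyl ethers

A few compounds are considered here, and "the series" means these few. Any claim that something is new, unique, unknown or untested is made for them only; others in the source may bear on it.

The series shares one core, carried in compound 1 `CCOC(=O)c1cc(-c2cccc(OCc3cccc(Br)c3)c2)on1`, compound 2 `CCOC(=O)c1cc(-c2cccc(OCc3cccc(C#N)c3)c2)on1` and compound 3 `CCOC(=O)c1cc(-c2cccc(OCc3cc(F)ccc3F)c2)on1`, and differs only in the aryl group on the benzyl ether. In an ADME assay on Vero cells (Chlorocebus sabaeus) for cytotoxicity, with a stated time of 72 h (on this read-out higher numbers stand for weaker inhibition and lower numbers for stronger inhibition), compound 1 reaches only the limit of the assay, > 128000 nM, so no number is known for it. Compound 2 likewise sits at a limit in this assay, > 128000 nM. Compound 3 also gives a limit in this assay, > 128000 nM. Accordingly the steps from compound 1 to compound 2 a step that the two limits leave unreadable from compound 1 to compound 2, from compound 1 to compound 3 a step that the two limits leave unreadable from compound 1 to compound 3 and from compound 2 to compound 3 a step that the two limits leave unreadable from compound 2 to compound 3 cannot be read, because of the limit of > 128000 nM in this assay, at which 3 of the 3 values shown sit.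

Compound 4 `CCOC(=O)c1cc(-c2cccc(OCc3ccc(F)cc3F)c2)on1` is not yet measured. Its change from compound 1 is 2,4-difluorophenyl in place of 3-bromophenyl on a saturated chain carbon bound to an oxygen on an aromatic ring. The step from compound 1 to compound 3 is the closest counterpart, a difluorophenyl entering in place of the same 3-bromophenyl at the same place, and it left compound 3 at the limit. Compound 4 is therefore expected to sit at or beyond the limit too, with an estimated step from compound 1 of a step that the limit leaves unreadable from compound 1 to compound 4. The estimate for compound 4 in this assay is 250000 nM, within 100000 nM to 600000 nM, and most likely reported only as a limit.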

Compound 4, half-maximal inhibitory concentration: > 128000 nM
Compound 4 gave a limit, no number; the forecaster's own chance of this, stated with the estimate: 90%; the middle value does not contradict the limit.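

In this assay, compound 4 joins compound 1, compound 2 and compound 3 at a limit, so none of its steps to those three compounds can be read, because all the values lie at that limit: the limit of > 128000 nM in this assay, at which 4 of the 4 values shown sit.

The compounds shown leave open what concentration would reach half-maximal inhibition for any of the four, and whether the aryl group on the benzyl ether changes the read-out at all.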